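The source may report more compounds than this note shows. Statements on the series, on what has been measured and on what is new or still open speak of the compounds shown alone.

Compound 3 `CNC(=O)c1cc(C(=O)NC2CC2)cn(Cc2cccc3[nH]ncc23)c1=O` gives 4 ug/mL in a physicochemical assay for solubility, read by HPLC, in simulated intestinal fluid, with a stated time of 16 h, tested at 125 ug/mL (a lower number here means a less soluble compound, a higher number a more soluble compound), the lowest of the three numbers in hand. Compound 1 `CNC(=O)c1cc(C(=O)NC2CC2)cn(Cc2cccc3cc[nH]c23)c1=O` gives 11 ug/mL and compound 2 `CNC(=O)c1cc(C(=O)NC2CC2)cn(Cc2cccc3[nH]ccc23)c1=O` gives 17 ug/mL; the steps of a 2.8-fold lower number from compound 1 to compound 3 (0.44 log units; beyond the scatter) and a 4.3-fold lower number from compound 2 to compound 3 (0.63 log units; beyond the scatter) are both beyond the scatter, while a 1.5-fold higher number from compound 1 to compound 2 (0.19 log units; within the scatter) is not. Compound 4 `CNC(=O)c1cc(C(=O)NC2CC2)cn(Cc2ccc(C)cc2)c1=O` differs from compound 3 by 4-methylphenyl in place of 1H-indazol-4-yl on a saturated chain carbon bound to an aromatic nitrogen. Going by the values given here, no measured step removes the two-ring group entirely; the three steps only exchange one two-ring group for another, and each of those exchanges moved the number by a modest amount at most. Among the compounds with values here, the present change goes further, trading a group with one hydrogen-bond donor and one acceptor for one with none, so the bearing of the earlier steps is indirect. The expected change for compound 4 is therefore a 2.0-fold higher number from compound 3 to compound 4 (0.30 log units; within the scatter), a modest rise but with the direction uncertain. Compound 4 is estimated at 8 ug/mL in this assay, within a range from 3 ug/mL to 25 ug/mL.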

Compound 4, solubility: 11 ug/mL
Beside the measured number, compound 4's estimate is 1.4-fold (0.14 log units) below it; low and high end bracket the measured number.
By their numbers in this assay, from the lowest: compound 3; then compounds 1, 4 and 2 (each within the scatter of the next).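

On a saturated chain carbon bound to an aromatic nitrogen, a fused two-ring group is not required for the numbers seen so far in this assay, since 4-methylphenyl, a single six-membered carbon ring with 0 hydrogen-bond donors, gives a 2.8-fold higher number from compound 3 to compound 4 (0.44 log units; beyond the scatter). Set against the two indole compounds, the same group gives a 1.5-fold lower number from compound 2 to compound 4 (0.19 log units; within the scatter) and no change at the digits printed from compound 1 to compound 4 (within the scatter), so among these four compounds only compound 3, with 1H-indazol-4-yl, stands apart, as the lowest. Nothing measured here accounts for the low number of compound 3.

On these data alone, it remains open how the number would respond to an amine or a carboxylic acid in place of the methyl of 4-methylphenyl, or to a longer chain there. As far as these compounds go, it is also open whether the level shared by compounds 1, 2 and 4 would hold on a different core.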